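The source may hold more compounds than are shown below. What is called first, only, known or untested is meant among the compounds shown, and "the series" means these compounds.

Of the compounds shown here, three that share one core have been measured in an assay on isolated protein for displacement of a labelled ligand from 5-hydroxytryptamine receptor 6 (Homo sapiens); on this read-out higher numbers stand for weaker inhibition and lower numbers for stronger inhibition. Compound 1 `CNCC(=O)NC[C@@H]1CCCc2cc(S(=O)(=O)c3cccc(F)c3)ccc21` gives 0.159 nM. Compound 2 `CN(C)C(=O)NC[C@@H]1CCCc2cc(S(=O)(=O)c3cccc(F)c3)ccc21` gives 2.51 nM, which is a 16-fold higher number from compound 1 to compound 2 (1.20 log units; beyond the scatter). Compound 3 `CN(C[C@@H]1CCCc2cc(S(=O)(=O)c3cccc(F)c3)ccc21)S(C)(=O)=O` gives 0.398 nM. Among the three numbers compound 3 stands second, with a 2.5-fold higher number from compound 1 to compound 3 (0.40 log units; beyond the scatter) and a 6.3-fold lower number from compound 2 to compound 3 (0.80 log units; beyond the scatter), both beyond the scatter.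

Compound 4 `NS(=O)(=O)NC[C@@H]1CCCc2cc(S(=O)(=O)c3cccc(F)c3)ccc21` has not yet been measured in this assay. It differs from compound 3 in one place: sulfamoylamino in place of methyl(methylsulfonyl)amino on a saturated chain carbon bound to a saturated ring carbon. Within the data shown here, two measured steps bear on this change, since both exchange the group at the same place: a 2.5-fold higher number from compound 1 to compound 3 (0.40 log units; beyond the scatter) and a 6.3-fold lower number from compound 2 to compound 3 (0.80 log units; beyond the scatter). Each was of modest size, and they ran in opposite directions, so the measured data give no clear direction for a further exchange at this place, only a sense of its likely size. A step of modest size is therefore expected, a 1.5-fold higher number from compound 3 to compound 4 (0.18 log units; within the scatter), with either direction possible. Compound 4 is estimated to give 0.6 nM in this assay, within a range from 0.15 nM to 2.5 nM.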

Compound 4, inhibition constant: 0.126 nM
Compound 4: the middle estimate sits 4.8-fold (0.68 log units) above what was measured; measured number outside the range, below it.
By their numbers in this assay, from the lowest: compounds 4 and 1 (each within the scatter of the next); then compound 3; then compound 2.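

In this assay, a 3.2-fold lower number from compound 3 to compound 4 (0.50 log units; beyond the scatter) shows that this place accepts sulfamoylamino: a group with hydrogen-bond donors replaces one without them, and the number falls rather than rises. a 20-fold lower number from compound 2 to compound 4 (1.30 log units; beyond the scatter) is a large step, whereas a 1.3-fold lower number from compound 1 to compound 4 (0.10 log units; within the scatter) lies within the scatter, so sulfamoyl and ((methylamino)methyl)carbonyl on the amine nitrogen cannot be ordered here, and compound 2 with dimethylcarbamoyl stays apart from both. No evidence at hand explains these differences.

Going from compound 3 to compound 4 changes two things at once, the methyl on the nitrogen and the methyl on the sulfonyl, so the compounds shown cannot say which one matters. Methylsulfonylamino, which has a hydrogen on that nitrogen and keeps the sulfonyl methyl, would separate the two, and an ethyl group on the sulfonyl remains open as well.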